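Two methyl groups added to the phenyl on the imine carbon

The source may hold more compounds than are shown below. What is called first, only, known or untested is meant among the compounds shown, and "the series" means these compounds.

For the measured compounds named here, compound 1 `c1ccc(C2=NN(C3=NC(c4ccccc4)CS3)C(c3cccc4ccccc34)C2)cc1` gives the highest of the two numbers so far: in a functional assay on BGC-823 cells (Homo sapiens) for inhibition, read by CCK-8 assay, with a stated time of 48 h (a lower number here means a stronger inhibitor, a higher number a weaker inhibitor), compound 1 gives 14300 nM. Going by the values given here, the only other compound, compound 2 `c1ccc(C2=NN(C3=NC(c4ccccc4)CS3)C(c3ccc4ccccc4c3)C2)cc1`, gives 9620 nM in this assay, and the step of a 1.5-fold lower number from compound 1 to compound 2 (0.17 log units; within the scatter) is the sole measured change; it touches the naphthyl group on a saturated ring carbon, not the part changed here. Compound 3 `Cc1ccc(C2=NN(C3=NC(c4ccccc4)CS3)C(c3cccc4ccccc34)C2)cc1C` differs from compound 1 by 3,4-dimethylphenyl in place of phenyl on a carbon with a double bond to nitrogen. Among the compounds with values here, no measured step bears directly on this change, and the one measured step of a different kind stayed within the scatter, so nothing suggests a large shift in either direction. The expected step of a 1.2-fold lower number from compound 1 to compound 3 (0.08 log units; within the scatter) is therefore small. Compound 3 is estimated to give 12000 nM in this assay, with a range from 4000 nM to 36000 nM.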

Compound 3, half-maximal inhibitory concentration: 8460 nM
Compound 3: the middle estimate sits 1.4-fold (0.15 log units) above what was measured; measured number inside the range.
By their numbers in this assay, from the lowest: compounds 3, 2 and 1 (each within the scatter of the next).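

In this assay, for the compounds shown here, the first direct reading of this position is a 1.7-fold lower number from compound 1 to compound 3 (0.23 log units; within the scatter). The place on a carbon with a double bond to nitrogen therefore takes 3,4-dimethylphenyl, with 8 heavy atoms, in place of phenyl, with 6, and the two compounds cannot be told apart by this measurement. Nothing available here explains this reading at the level of the molecule.

Going by these compounds, whether either methyl group alone would read the same remains open, as does the effect of a different kind of group on this phenyl ring, such as a carboxylic acid or an amine. Also open, on these data alone, is whether 3,4-dimethylphenyl would give a similar reading on compound 2, which carries naphthalen-2-yl rather than naphthalen-1-yl.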